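The source may hold more compounds than are shown below. What is called first, only, known or untested is meant among the compounds shown, and "the series" means these compounds.

Measured compounds:
Compound 1, `CCCCCCCCC#CCSCc1cccc(CCC(=O)O)c1`. In an assay on isolated protein for inhibition of Arachidonate 12-lipoxygenase (Sus scrofa) (on this read-out higher numbers stand for weaker inhibition and lower numbers for stronger inhibition), compound 1 gives > 10000 nM, which is a limit of the assay rather than a number.
Compound 2, `CCCCCCCCCCC#CCOCc1cccc(CCC(=O)O)c1`. In this assay compound 2 gives 320 nM.

Among the measured compounds shown here, compound 2 therefore stands alone as the only number recorded in this assay; the other value is a limit (the limit of > 10000 nM in this assay, at which 1 of the 2 values shown sits). For the measured compounds named here, compound 1 and compound 2 differ in more than one place, so no step between them is recorded; their two values show only that one is a limit and the other a number.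

Compound 3, `O=C(O)CCc1cccc(COCC#CCCCCCc2ccccc2)c1`, follows from compound 2 by phenyl in place of pentyl on a saturated chain carbon, five bonds along the chain from a triple-bonded carbon. Going by the values given here, with no measured step of this kind to lean on, the step is expected to be modest and of uncertain direction, probably within the scatter, a 1.6-fold higher number from compound 2 to compound 3 (0.19 log units; within the scatter). Compound 3 is estimated at 500 nM in this assay, with a range from 100 nM to 3000 nM.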

Compound 3, half-maximal inhibitory concentration: 5000 nM
The estimate for compound 3 lay 10-fold (1.00 log units) below the measured number, and the stated range ends below it.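

Among the compounds shown here, putting phenyl in place of pentyl on a saturated chain carbon, five bonds along the chain from a triple-bonded carbon, gives a 16-fold higher number from compound 2 to compound 3 (1.19 log units; beyond the scatter) in this assay, the only step that can be read here. The far end of the chain is therefore not a place where a change passes without effect: in this one pair, the aromatic ring goes with weaker inhibition than the open pentyl end. Nothing at hand gives a reason for this step.

The compounds shown leave open whether a cyclohexyl group in the same place would read like the phenyl or like the pentyl. They also leave open whether a longer chain leading to the phenyl, or a fluorine on it, would bring the number back down.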